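Acetylation of the hydroxy group of compound 3

The compounds below may be only part of what the source reports. "The series", "measured", "known", "first", "only" and "open" are said of these compounds alone.

Measured in an ADME assay on ECV-304 cells (Homo sapiens) for cytotoxicity, read by MTT assay, with a stated time of 72 h; a lower number here means a stronger inhibitor, a higher number a weaker inhibitor:
Compound 1 `COc1ccc(C2=C(c3cc(OC)c(OC)c(OC)c3)C(=O)CC2C)cc1C(=O)O`: > 100 ug/mL
Compound 2 `COc1ccc(C2=C(c3cc(OC)c(OC)c(OC)c3)C(=O)CC2O[SiH2]C(C)(C)C)cc1`: > 100 ug/mL
Compound 3 `COc1cc(C2=C(c3cc(C)c(OC)c(C)c3)C(O)CC2=O)cc(OC)c1OC`: > 100 ug/mL

All three entries are limits of the assay and not numbers. The set shows (the limit of > 100 ug/mL in this assay, at which 3 of the 3 values shown sit). Among the compounds with values here, no compound in it can therefore be ranked against another, and no measured step between two compounds is available.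

Compound 3 gives > 100 ug/mL, which is a limit.

Compound 4 `COc1cc(C2=C(c3cc(C)c(OC)c(C)c3)C(OC(C)=O)CC2=O)cc(OC)c1OC` is the next compound to be read in this assay. It carries acetyl in place of hydrogen on an oxygen on a saturated carbon, that is, hydroxy to acetoxy (acetyl in place of hydrogen on an oxygen on a saturated carbon).

Within the data shown here, with no measured pair to draw on, the size of this change cannot be taken from the series. Among the measured compounds shown here, the only guide is the limit of > 100 ug/mL in this assay, at which 3 of the 3 values shown sit, so the most likely outcome for compound 4 is expected to be another limit result. No direction is favoured, and no shift beyond the usual scatter is expected.

The expected size of the change is a number no higher from compound 3 to compound 4 (the limit leaves the size open).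

For compound 4 the estimate is 100 ug/mL, with an expected range from 30 ug/mL to 200 ug/mL.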

Compound 4, half-maximal inhibitory concentration: > 100 ug/mL
Compound 4: a limit, no number (the forecaster's own chance of this, stated with the estimate: 70%); the middle value sits exactly at the limit.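

Compound 3 and compound 4 both give limits and not numbers, so the step from hydroxy to acetoxy cannot be read. The compounds shown leave open whether this change alters the read-out at all, and how compounds 1 to 4 would rank, as all four results remain at the same limit: the limit of > 100 ug/mL in this assay, at which 4 of the 4 values shown sit.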